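The source may hold more compounds than are shown below. What is called first, only, known or untested is meant among the compounds shown, and "the series" means these compounds.

Measured so far in a functional assay on A549 cells (Homo sapiens) for cytotoxicity, read by MTT assay; a higher number here means a weaker inhibitor, a lower number a stronger inhibitor:

compound 1, `CCc1cc(S(=O)(=O)N2C[C@H](c3ccccc3)NC2=O)ccc1NC(=O)OC(C)C` — 60 nM
compound 2, `CCOC(=O)Nc1ccc(S(=O)(=O)N2C[C@H](c3ccccc3)NC2=O)cc1CC` — 60 nM
compound 3, `CCc1cc(S(=O)(=O)N2C[C@H](c3ccccc3)NC2=O)ccc1NC(=O)NC1CCCCC1` — 500 nM

Compound 3 stands highest of the three numbers. Both alkoxy groups on the carbonyl carbon give the same reading, no change at the digits printed from compound 1 to compound 2 (within the scatter), whereas the urea-type substituent sits apart: an 8.3-fold higher number from compound 1 to compound 3 (0.92 log units; beyond the scatter) and an 8.3-fold higher number from compound 2 to compound 3 (0.92 log units; beyond the scatter).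

Compound 4, `CCc1cc(S(=O)(=O)N2C[C@H](c3ccccc3)NC2=O)ccc1NC(=O)c1ccc(N)cc1`, is the next point on this carbonyl carbon: 4-aminophenyl in place of cyclohexylamino on a carbonyl carbon. Among the compounds with values here, no measured step covers a carbon substituent on this carbonyl; the two steps that bear on the position, an 8.3-fold higher number from compound 1 to compound 3 (0.92 log units; beyond the scatter) and an 8.3-fold higher number from compound 2 to compound 3 (0.92 log units; beyond the scatter), show only that cyclohexylamino gives a higher number than either alkoxy group, and compound 3 is the sole compound with a nitrogen-linked group there. The expectation is therefore weakly founded: a modest move back toward the alkoxy readings is plausible, but a step in either direction, or none beyond the scatter, cannot be excluded. The expected step is a 2.5-fold lower number from compound 3 to compound 4 (0.40 log units; beyond the scatter). For compound 4 in this assay the estimate is 200 nM, within the range 40 nM to 1000 nM.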

Compound 4, half-maximal inhibitory concentration: 220 nM
Beside the measured number, compound 4's estimate is 1.1-fold (0.04 log units) below it, and the stated range covers the measured number.
By their numbers in this assay, from the lowest: compounds 1 and 2 (each within the scatter of the next); then compound 4; then compound 3.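

In this assay, a carbon-linked ring on this carbonyl carbon gives an intermediate reading: 4-aminophenyl shows a 2.3-fold lower number from compound 3 to compound 4 (0.36 log units; beyond the scatter) and also a 3.7-fold higher number from compound 2 to compound 4 (0.56 log units; beyond the scatter) and a 3.7-fold higher number from compound 1 to compound 4 (0.56 log units; beyond the scatter). The position therefore separates three levels among the compounds shown, with both alkoxy groups lowest, 4-aminophenyl next and cyclohexylamino highest. Cyclohexylamino and 4-aminophenyl have the same heavy-atom count, so that count does not account for the gap between them, and no measurement shown gives a reason for the differences at this position.

The step from cyclohexylamino to 4-aminophenyl changes the linking atom, the ring and the amine together, so the share of each remains unresolved. Phenyl, phenylamino or cyclohexyl on this carbonyl carbon would separate those contributions.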